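The source may report more compounds than this note shows. Statements on the series, on what has been measured and on what is new or still open speak of the compounds shown alone.

Measured compounds and values in an assay for inhibition of histone deacetylase 8 (Homo sapiens), read by fluorescence, with stated times of 15 min and 60 min; a higher number here means a weaker inhibitor, a lower number a stronger inhibitor:
compound 1 `Nc1ccccc1NC(=O)c1ccc(CNC2=N[C@@H](Cc3ccccc3)CS2)cc1`: 34900 nM
compound 2 `Nc1ccccc1NC(=O)c1ccc(CNC2=N[C@H](Cc3ccccc3)CS2)cc1`: 12700 nM

Compound 1 gives the higher of the two numbers: compound 2, its nearest neighbour, shows a 2.7-fold lower number from compound 1 to compound 2 (0.44 log units; beyond the scatter), a step that rests on the fact that compounds 1 and 2 differ only in the configuration as drawn and touches no group at all. Compound 3 `Nc1ccccc1NC(=O)c1ccc(CNC2=N[C@@H](c3ccc(O)cc3)CS2)cc1` keeps the configuration drawn for compound 1 and instead carries 4-hydroxyphenyl in place of benzyl on a saturated ring carbon, 4-hydroxyphenyl in place of benzyl on a saturated ring carbon. Within the data shown here, no measured step swaps one group for another at this position, so the only step available does not bear on this change. Without such a reference, the expected outcome is no step beyond the scatter, and compound 3 is therefore estimated at 30000 nM, within a wide range from 8000 nM to 110000 nM. The step this expectation implies is a 1.2-fold lower number from compound 1 to compound 3 (0.07 log units; within the scatter).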

Compound 3, half-maximal inhibitory concentration: 15000 nM
Estimate against measurement, compound 3: 2.0-fold (0.30 log units) above; low and high end bracket the measured number.
By their numbers in this assay, from the lowest: compounds 2 and 3 (each within the scatter of the next); then compound 1.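

Until now only the drawn configuration at this saturated ring carbon had varied; here the group on it changes while the configuration stays as in compound 1. In this assay, 4-hydroxyphenyl in place of benzyl gives a 2.3-fold lower number from compound 1 to compound 3 (0.37 log units; beyond the scatter), so the identity of the group at this position also shifts the number, not only its configuration. The two groups have the same number of heavy atoms, but only 4-hydroxyphenyl has a hydrogen-bond donor and acceptor, and nothing shown here explains why the swap lowers the number.

The swap both adds a hydroxyl and removes the carbon that links the aromatic ring to the saturated ring, so its two parts cannot be separated. Going by these compounds, a plain phenyl or a 4-hydroxybenzyl group at this position would tell them apart, and how 4-hydroxyphenyl behaves in the opposite configuration remains open.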